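Alkyl ketone variation on the shared core, allosteric modulation

The compounds below may be only part of what the source reports. "The series", "measured", "known", "first", "only" and "open" are said of these compounds alone.

Measured compounds:
compound 1, `Cc1c(OCCCCOc2ccc(C(=O)O)cc2Cl)ccc(C(=O)CC2CCCC2)c1O`, 237 nM
compound 2, `CCC(=O)c1ccc(OCCCCOc2cc(C(=O)O)ccc2OC)c(C)c1O`, 162 nM

Both compounds carry the same diaryl ether-linked core with a carboxylic acid on one ring and an aryl ketone on the other. In an assay on HEK293 cells for positive allosteric modulation of metabotropic glutamate receptor 2 (Rattus norvegicus), read by thallium flux, with a stated time of 2.5 min (a lower number here means that less compound is needed, a higher number that more compound is needed for the effect), compound 1 gives 237 nM, and in this assay compound 2 gives 162 nM. The two numbers lie within the usual scatter of each other, so nothing separates compound 1 from compound 2 on what has been measured; compound 2 is simply the reference point for the next step.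

Compound 3, `COc1ccc(C(=O)O)cc1OCCCCOc1ccc(C(=O)CC(C)C)c(O)c1C`, has not yet been measured in this assay. It differs from compound 2 in one place: isopropyl in place of methyl on a saturated chain carbon bound to a carbonyl carbon. The change keeps donor and acceptor count unchanged and adds only saturated carbon on the chain bound to the carbonyl carbon.

Within the data shown here, no measured pair shows what such a chain extension does, so there is no step to lean on. The expectation for compound 3 is therefore a step of a 1.2-fold higher number from compound 2 to compound 3 (0.09 log units; within the scatter), which is no change beyond the scatter, and compound 3 is estimated at 200 nM with a range from 70 nM to 600 nM.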

Compound 3, half-maximal effective concentration: 155 nM
Compound 3: middle estimate off by 1.3-fold (0.11 log units), on the high side; low and high end bracket the measured number.
By their numbers in this assay, from the lowest: compounds 3, 2 and 1 (each within the scatter of the next).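

In this assay, among these compounds, isopropyl in place of methyl on a saturated chain carbon bound to a carbonyl carbon gives a 1.0-fold lower number from compound 2 to compound 3 (0.02 log units; within the scatter) and is the first step that can be read at this position. On this core, the position therefore accepts the change from ethyl to isobutyl, with its two extra carbons and branch, without any shift beyond the scatter, although this rests on a single pair and says nothing about the position on other cores. Nothing measured on these compounds accounts for the flat result.

As far as these compounds go, whether the number stays flat with a longer chain, a phenyl ring, a hydroxyl or an amine on the same chain carbon remains open, so the limit of what this position accepts is not yet marked. Compound 1 differs from compound 2 and from compound 3 in more than one place, so steps to it cannot be read, and its side chain on the carbonyl adds nothing separable to this picture.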